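Shortening the acid side chain of a weak E-selectin ligand

A few compounds are considered here, and "the series" means these few. Any claim that something is new, unique, unknown or untested is made for them only; others in the source may bear on it.

Compound 1 `O=C(O)CC[C@H](NC(=O)CC1OC(CO)C(O)C(O)C1O)C(=O)O` — in an assay on isolated protein for binding affinity to E-selectin (Homo sapiens) (on this read-out higher numbers stand for weaker inhibition and lower numbers for stronger inhibition), compound 1 gives 3000000 nM
Compound 2 `O=C(O)CC[C@@H](NC(=O)CC1OC(CO)C(O)C(O)C1O)C(=O)O` — in this assay compound 2 gives 7000000 nM

For the measured compounds named here, compound 2 holds the highest of the two numbers; the only measured step, a 2.3-fold higher number from compound 1 to compound 2 (0.37 log units; beyond the scatter), is a drawn change of configuration alone, with the fact that one of compounds 1 and 2 is drawn with a defined configuration and the other without, at the place where they differ as the sole pointer to its cause. Compound 3 `O=C(O)C[C@@H](NC(=O)CC1OC(CO)C(O)C(O)C1O)C(=O)O` carries carboxy in place of carboxymethyl on a saturated chain carbon, two bonds along the chain from an amide-type nitrogen and a carbonyl carbon. Going by the values given here, no measured step touches such a chain shortening, so compound 3 is expected to sit near compound 2, with no change at the digits printed from compound 2 to compound 3 (within the scatter) falling within the scatter. Compound 3 is therefore estimated at 7000000 nM, between 2000000 nM and 25000000 nM.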

Compound 3, half-maximal inhibitory concentration: 6000000 nM
Compound 3: middle estimate off by 1.2-fold (0.07 log units), on the high side; the measured number falls inside the stated range.
By their numbers in this assay, from the lowest: compounds 1, 3 and 2 (each within the scatter of the next, the first and the last beyond it).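

In this assay, cutting 2-carboxyethyl to carboxymethyl gives a 1.2-fold lower number from compound 2 to compound 3 (0.07 log units; within the scatter) and so leaves the number at this position unmoved, where the earlier pair had shown only a change of configuration. The length of this acid side chain, over this single change, therefore makes no difference that can be told from the scatter. Nothing measured here bears on why the two numbers stay so close.

As far as these compounds go, it remains open whether a longer chain, or an amine in place of the carboxy group, would shift the number at this position. Also open, from the compounds shown here alone, is whether the shortened chain responds to the opposite configuration at this carbon as the longer one does.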